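Fluorophenyl for Hydroxyphenyl on a Benzoxazole Sulfonamide

The compounds below may be only part of what the source reports. "The series", "measured", "known", "first", "only" and "open" are said of these compounds alone.

Compound 1 `O=S(=O)(Nc1ccc(-c2nc3ccccc3o2)cc1)c1ccccc1O` was examined in an assay on cells for inhibition of HSP60/HSP10 (Homo sapiens), with a stated time of 60 min; a higher number here means a weaker inhibitor, a lower number a stronger inhibitor. In this assay compound 1 gives only a limit of > 100000 nM, not a number. Compound 2 `CS(=O)(=O)Nc1ccc2oc(-c3ccccc3)nc2c1` likewise reaches only the limit of > 100000 nM in this assay. Compound 3 `O=[N+]([O-])c1cc(S(=O)(=O)Nc2ccc3oc(-c4ccccc4)nc3c2)ccc1Cl` gives a measured value in this assay of 17000 nM. Compound 1 therefore stands at the limit of > 100000 nM in this assay, at which 2 of the 3 values shown sit, with no real number of its own. Compound 4 `O=S(=O)(Nc1ccc(-c2nc3ccccc3o2)cc1)c1cccc(F)c1` differs from compound 1 in one place: 3-fluorophenyl in place of 2-hydroxyphenyl on a sulfonyl sulfur. Within the data shown here, no measured pair shows this change, so its effect is unknown. The step is expected to be an at least 1.2-fold lower number from compound 1 to compound 4 (0.09 log units; that floor lies within the scatter), which amounts to no clear shift beyond the usual scatter. Compound 4 is expected to give an estimated 80000 nM, with a range from 20000 nM to 300000 nM.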

Compound 4, half-maximal inhibitory concentration: 71000 nM
The estimate for compound 4 lay 1.1-fold (0.05 log units) above the measured number, and the stated range covers the measured number.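

With 3-fluorophenyl on the sulfonyl sulfur, compound 4 gives a real number at this position, where compound 1 gave none. The change yields an at least 1.4-fold lower number from compound 1 to compound 4 (0.14 log units; that floor lies within the scatter), so no clear gain is shown, although the true step could be larger. Compound 1 marks only one end of this comparison, as a limit and not a number: the limit of > 100000 nM in this assay, at which 2 of the 4 values shown sit.

The compounds shown leave open whether losing the hydroxyl or gaining the fluorine accounts for the step. They also leave open how an unsubstituted phenyl, or a methoxy or amine on that ring, would read.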